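A few compounds are considered here, and "the series" means these few. Any claim that something is new, unique, unknown or untested is made for them only; others in the source may bear on it.

In a physicochemical assay for solubility, read by mass spectrometry, in phosphate buffer, with a stated time of 24 h, at pH 3 (on this read-out lower numbers stand for lower solubility and higher numbers for higher solubility), compound 2 (`Cc1occc1C(=O)N1CCC(NC(=O)Nc2ccc(OC(F)(F)F)cc2)CC1`) gives 7.7 ug/mL and holds the second highest of the three numbers in hand. On the same read-out compound 3 (`Cc1ccoc1C(=O)N1CCC(NC(=O)Nc2ccc(OC(F)(F)F)cc2)CC1`) gives 3.4 ug/mL and compound 1 (`O=C(Nc1ccc(C(F)(F)F)cc1)NC1CCN(C(=O)C2CCCOC2)CC1`) gives 25 ug/mL.

Compound 4 (`O=C(Nc1ccc(OC(F)(F)F)cc1)NC1CCN(C(=O)C2=COCC2)CC1`) departs from compound 2 in one place only, with a group of 5 heavy atoms (4 carbon, 1 oxygen; one five-membered non-aromatic ring with 1 hetero atom) in place of a group of 6 heavy atoms (5 carbon, 1 oxygen; one five-membered aromatic ring with 1 hetero atom), on a carbonyl carbon as the whole change. The entering group has 1 double bond outside aromatic rings, and neither group carries a net charge.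

Within the data shown here, one measured step bears directly on this place: a 2.3-fold lower number from compound 2 to compound 3 (0.36 log units; beyond the scatter) for 3-methylfuran-2-yl in place of 2-methylfuran-3-yl on a carbonyl carbon. Among the measured compounds shown here, that step is modest and lies beyond the scatter, but it keeps an aromatic ring, so no measured step yet covers a change to a non-aromatic ring in this setting. Compound 1 does carry a non-aromatic group on the carbonyl carbon and reads 25 ug/mL but it also differs elsewhere, so it offers only a loose hint on the higher side.

No step beyond the scatter is expected in this assay, and the estimated move is a 1.4-fold higher number from compound 2 to compound 4 (0.15 log units; within the scatter) on that basis. For compound 4 the estimate is 11 ug/mL (expected range 4 ug/mL to 30 ug/mL).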

Compound 4, solubility: 73 ug/mL
For compound 4 the middle estimate is 6.6-fold (0.82 log units) below the measured one; the whole stated range lies below it.
By their numbers in this assay, from the lowest: compound 3; then compound 2; then compound 1; then compound 4.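

In this assay, the place on the carbonyl carbon shows a much wider reach than the exchange of one methylfuran for the other suggested: that exchange gives a 2.3-fold lower number from compound 2 to compound 3 (0.36 log units; beyond the scatter), whereas the non-aromatic five-membered ring gives a 9.5-fold higher number from compound 2 to compound 4 (0.98 log units; beyond the scatter). The higher number holds against both aromatic groups, with a 21-fold higher number from compound 3 to compound 4 (1.33 log units; beyond the scatter), so the result does not rest on one methylfuran isomer alone. Nothing in hand accounts for the size of these steps.

The change replaces an aromatic ring with a non-aromatic one and also goes from 6 heavy atoms to 5, so the compounds shown do not separate the ring type from the loss of the methyl group, and they do not show whether the gain would survive on a methyl-bearing version of the same non-aromatic ring. Also open, on these data alone, is how a fully saturated tetrahydrofuran ring, an amine or a carboxylic acid on this carbonyl carbon would read, and whether the same order of compounds holds away from the single pH covered here.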